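The source may hold more compounds than are shown below. What is called first, only, known or untested is meant among the compounds shown, and "the series" means these compounds.

Working notes on the series. Compound 1 `CC(C)(C)c1ccc(C(=O)NCc2ccc(C(N)=O)cc2)cc1` and compound 2 `CC(C)(C)c1ccc(C(=O)NCc2ccc(OC(F)(F)F)cc2)cc1` share one core and differ only at the group on the terminal aromatic ring. Among the compounds with values here, in an assay on HeLa cells with Bile acid receptor (Homo sapiens) as the target, read by a luciferase reporter, with a stated time of 24 h (a lower number here means that less compound is needed, a higher number that more compound is needed for the effect), compound 1 gives 3800 nM, while compound 2 gives 160 nM; the step of a 24-fold lower number from compound 1 to compound 2 (1.38 log units; beyond the scatter) is the only measured step in this assay so far. Among the two numbers in this assay, compound 2 stands lowest, with compound 1 as its nearest neighbour.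

Compound 3 `CC(=O)Nc1ccc(CNC(=O)c2ccc(C(C)(C)C)cc2)cc1` is not yet measured. It differs from compound 2 by acetamido in place of trifluoromethoxy on an aromatic carbon. Within the data shown here, the only step that bears on it is the one from compound 1 to compound 2, in which a group carrying a hydrogen-bond donor was exchanged for trifluoromethoxy and the number fell by a large amount; here the exchange runs the other way, from trifluoromethoxy back to a group with one hydrogen-bond donor and one acceptor. A step in this assay of roughly that size, but toward a higher number, is therefore expected for compound 3, estimated as a 9.4-fold higher number from compound 2 to compound 3 (0.97 log units; beyond the scatter). The expected value for compound 3 in this assay is 1500 nM, with a range from 400 nM to 5500 nM.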

Compound 3, half-maximal effective concentration: 2900 nM
Beside the measured number, compound 3's estimate is 1.9-fold (0.29 log units) below it; the measured number falls inside the stated range.
By their numbers in this assay, from the lowest: compound 2; then compounds 3 and 1 (each within the scatter of the next).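

At this position, para to a large group, the low number of compound 2 in this assay is not kept when acetamido enters: the step is an 18-fold higher number from compound 2 to compound 3 (1.26 log units; beyond the scatter). Acetamido and carbamoyl give matching results, with a 1.3-fold lower number from compound 1 to compound 3 (0.12 log units; within the scatter), so the two amide-type groups, each carrying a hydrogen-bond donor, sit at one level while trifluoromethoxy, without a donor, stands apart; among these three compounds none goes against this split, and it is claimed for no others. No measurement at hand gives a reason for the split.

The compounds shown leave open whether the hydrogen-bond donor or the fluorine atoms of trifluoromethoxy set the level, since each exchange changes both at once. A methoxy group would keep the oxygen without the fluorine, a trifluoromethyl group would keep the fluorine without the oxygen, and an N-methylacetamido group would keep the acetamido frame without the amide hydrogen, so each of these would separate the two readings at this position.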